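A few compounds are considered here, and "the series" means these few. Any claim that something is new, unique, unknown or untested is made for them only; others in the source may bear on it.

Compound 2 `CCOC(=O)Cn1c(=O)n(C2OC(CO)[C@@H](O)[C@H]2O)c2nc(N)nc(O)c21` is the lower of the two measured compounds in a functional assay on the whole organism (B cells) with Mus musculus as the target; a higher number here means a larger maximal response, a lower number a smaller maximal response; compound 2 gives 86%. Compound 1 `Nc1nc(O)c2c(n1)n(C1OC(CO)[C@@H](O)[C@H]1O)c(=O)n2CC(O)CO` carries 1,2-dihydroxyethyl where compound 2 carries ethoxycarbonyl on the saturated chain carbon bound to the aromatic nitrogen. In this assay compound 1 gives 136%. Within the data shown here, the one measured step is a number 50 percentage points lower from compound 1 to compound 2 (beyond the scatter). Compound 3 `CCCCCCCCCCn1c(=O)n(C2OC(CO)[C@@H](O)[C@H]2O)c2nc(N)nc(O)c21` differs from compound 2 as follows: nonyl in place of ethoxycarbonyl on a saturated chain carbon bound to an aromatic nitrogen. Among the measured compounds shown here, no measured step exchanges ethoxycarbonyl for nonyl, so the step from compound 1 to compound 2 bears on it only in showing that a change at this position can move the maximal response by a large amount. The direction for compound 3 cannot be read from the two numbers at hand. For compound 3 a step of a number 9 percentage points higher from compound 2 to compound 3 (within the scatter) is therefore expected, with a wide range. Compound 3 is estimated at 95%, between 50% and 140%.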

Compound 3, largest response reached (reported as maximal response), in percent of the reference or control that the assay uses: 0%
Compound 3: the middle estimate sits 95 percentage points above what was measured; measured number outside the range, below it.
By their numbers in this assay, from the lowest: compound 3; then compound 2; then compound 1.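

In this assay the place on a saturated chain carbon bound to an aromatic nitrogen can do more than lower the maximal response: compound 3 gives 0%, the bottom of the series, with a number 86 percentage points lower from compound 2 to compound 3 (beyond the scatter) and a number 136 percentage points lower from compound 1 to compound 3 (beyond the scatter). Among the compounds shown, the two groups containing oxygen, ethoxycarbonyl and 1,2-dihydroxyethyl, keep a response, whereas the all-carbon nonyl does not. No measurement here accounts for this loss.

Nonyl differs from ethoxycarbonyl both in its length and in lacking oxygen, and the compounds shown do not separate these two differences. A short chain such as propyl, or a nonyl chain ending in a carboxylic acid or an amine, would tell them apart.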